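This account rests on a few compounds, and the source may have more. Where it says the series, first, only, none or still open, it means among the compounds named here.

Measured so far:

Compound 1 `CN1CCN(CC(=O)NC2CC3(N4CCCC4)CC(c4ccccc4)C2C(c2ccccc2)C3)CC1` — in an ADME assay on L6 cells (Rattus norvegicus) for cytotoxicity, read by resazurin assay, with a stated time of 72 h (on this read-out lower numbers stand for stronger inhibition and higher numbers for weaker inhibition), compound 1 gives 50200 nM.
Compound 2 `O=C(CN1CCCCC1)OC1CC2(N3CCCC3)CC(c3ccccc3)C1C(c1ccccc1)C2` — in this assay compound 2 gives 14200 nM.
Compound 3 `O=C(CN1CCCCC1)OC1CC2(N3CCCCC3)CC(c3ccccc3)C1C(c1ccccc1)C2` — in this assay compound 3 gives 60400 nM.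

Compound 4 `CN1CCN(CC(=O)NC2CC3(N4CCCCC4)CC(c4ccccc4)C2C(c2ccccc2)C3)CC1` has not yet been measured.

The change that carries compound 2 to compound 1 is (((4-methylpiperazin-1-yl)methyl)carbonyl)amino in place of (((piperidin-1-yl)methyl)carbonyl)oxy on a saturated ring carbon and in this assay it made a 3.5-fold higher number from compound 2 to compound 1 (0.55 log units; beyond the scatter). The cores of compound 2 and compound 3 differ by piperidin-1-yl in place of pyrrolidin-1-yl on a saturated ring carbon, which in this assay gave a 4.3-fold higher number from compound 2 to compound 3 (0.63 log units; beyond the scatter); compound 3 stands highest of the three measured numbers, but its gap to compound 1 is within the scatter.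

The change from compound 3 to compound 4 is (((4-methylpiperazin-1-yl)methyl)carbonyl)amino in place of (((piperidin-1-yl)methyl)carbonyl)oxy on a saturated ring carbon. The surroundings are not identical: in compound 1 the place lies two ring bonds from the ring atom that bears a pyrrolidin-1-yl group, in compound 4 two ring bonds from the ring atom that bears a piperidin-1-yl group, so it is the same kind of change, not the same one. Among the compounds with values here, only one earlier example exists, so the expectation rests on the single step of a 3.5-fold higher number from compound 2 to compound 1 (0.55 log units; beyond the scatter) from compound 2 to compound 1 and on the value of compound 3, 60400 nM. For compound 4 a step of about a 2.6-fold higher number from compound 3 to compound 4 (0.42 log units; beyond the scatter) in this assay is expected, near the earlier one. Compound 4 is therefore estimated at 160000 nM, with a range from 60000 nM to 400000 nM; a value this high may only be reported as a limit.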

Compound 4, half-maximal inhibitory concentration: 57500 nM
Compound 4: the middle estimate sits 2.8-fold (0.44 log units) above what was measured; measured number below the stated range.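

In this assay, (((4-methylpiperazin-1-yl)methyl)carbonyl)amino in place of (((piperidin-1-yl)methyl)carbonyl)oxy gives a 1.1-fold lower number from compound 3 to compound 4 (0.02 log units; within the scatter), so the step seen on the core bearing pyrrolidin-1-yl does not carry over to the core bearing piperidin-1-yl: the same change on two cores in this assay, a 3.5-fold higher number (0.55 log units; beyond the scatter) from compound 2 to compound 1 and a 1.1-fold lower number (0.02 log units; within the scatter) from compound 3 to compound 4, 3.7-fold (0.57 log units) apart, beyond the scatter of two such steps. Read the other way, with (((4-methylpiperazin-1-yl)methyl)carbonyl)amino in place, piperidin-1-yl in place of pyrrolidin-1-yl gives a 1.1-fold higher number from compound 1 to compound 4 (0.06 log units; within the scatter), so this step also depends on its surroundings: the same change on two cores in this assay, a 4.3-fold higher number (0.63 log units; beyond the scatter) from compound 2 to compound 3 and a 1.1-fold higher number (0.06 log units; within the scatter) from compound 1 to compound 4, 3.7-fold (0.57 log units) apart, beyond the scatter of two such steps. The two changes therefore do not add up across these four compounds, but this single set cannot say why, or whether the same holds on any other core.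

The compounds shown leave open whether the ester oxygen or the 4-methylpiperazine ring accounts for the step from compound 2 to compound 1, a question that (((piperidin-1-yl)methyl)carbonyl)amino would separate. Also open, on these data alone, is how other amines on the ring carbon, such as morpholine or dimethylamine, would behave with either side chain.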